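A few compounds are considered here, and "the series" means these few. Any claim that something is new, unique, unknown or untested is made for them only; others in the source may bear on it.

Measured compounds:
- compound 1, `CCCCCCCCc1ccc(OCC(=O)Cn2nnc(-c3ccc(Cl)cc3)n2)cc1`: 74%
- compound 2, `CC(Oc1ccc(Oc2ccc(F)cc2)cc1)C(=O)Cn1nnc(-c2ccccc2)n1`: < 5%
- compound 3, `CCCCCCCCc1ccc(OC(C)C(=O)Cn2nnc(-c3ccc(Cl)cc3)n2)cc1`: 72%

In an ADME assay on S9 fraction from liver (Rattus norvegicus) for metabolic stability, read by LC-MS, using NADPH, with a stated time of 30 min (a lower number here means that less of the compound is left, a higher number that more of the compound is left), compound 1 gives 74% and compound 3 gives 72%. Compound 2 gives < 5%, which is a limit of the assay and not a number; it is one of the cases described by the limit of < 5% in this assay, at which 1 of the 3 values shown sits. Compound 3 thus sits at the lower of the two plain numbers, with compound 1 as its nearest neighbour, and the gap between them lies within the scatter. Among the measured compounds shown here, the one measured step, a number 2 percentage points lower from compound 1 to compound 3 (within the scatter), changed a saturated chain carbon only.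

Compound 4, `CC(Oc1ccc(Oc2ccc(F)cc2)cc1)C(=O)Cn1nnc(-c2ccc(Cl)cc2)n1`, arises from compound 3 by 4-fluorophenoxy in place of octyl on an aromatic carbon. For the measured compounds named here, no measured step covers this exchange of one chain for one ring. What can be said is that compound 2 also carries a 4-fluorophenoxy group and gives < 5%, a limit, while compound 3 with its octyl group gives 72%. On that ground a large downward step a number 62 percentage points lower from compound 3 to compound 4 (beyond the scatter) is expected, and compound 4 is estimated at 10%, between 0% and 35%.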

Compound 4, percent of the compound remaining: < 5%
Compound 4 was reported as a limit (the forecaster's own chance of this, stated with the estimate: 45%); at least 5 percentage points between middle value and limit.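

In this assay, 4-fluorophenoxy in place of octyl gives a number at least 67 percentage points lower from compound 3 to compound 4 (beyond the scatter), so this single exchange on an aromatic carbon is tied to a large change in how much compound remains. Compound 2 and compound 3 differ in more than one place, so they could not isolate this exchange, and the earlier methyl step on the saturated chain carbon stayed within the scatter. The value of compound 4, < 5%, is a limit of the assay and not a number.

The effect of chloro in place of hydrogen cannot be read, because compound 2 and compound 4 both sit at a limit: the limit of < 5% in this assay, at which 2 of the 4 values shown sit. The compounds shown leave open how much compound would remain with a shorter chain, an amine or a carboxylic acid on this aromatic carbon.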